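Swapping Chlorine for Fluorine on a Glutamate Receptor Modulator

The compounds below may be only part of what the source reports. "The series", "measured", "known", "first", "only" and "open" are said of these compounds alone.

Compound 1 `CCCCn1ccc(-c2ccc(Oc3ccnc(C)c3)c(Cl)c2)c(C#N)c1=O` and compound 3 `CCCCn1ccc(-c2ccc(Oc3ccnc(C)c3)c(F)c2)c(C#N)c1=O` share one core. In a functional assay on CHO cells for positive allosteric modulation of metabotropic glutamate receptor 2 (Homo sapiens), read by scintillation counting and GTPgammaS binding, with a stated time of 30 min (a higher number here means that more compound is needed for the effect, a lower number that less compound is needed), compound 1 gives 166 nM, and compound 3 gives 316 nM. The change between them, (fluoro in place of chloro on an aromatic carbon), produced a 1.9-fold higher number from compound 1 to compound 3 (0.28 log units; within the scatter). Compound 2 `CCCCn1ccc(-c2ccc(Oc3ccnc(C)c3)cc2Cl)c(C#N)c1=O` is built from the same atoms as compound 1, joined differently; the difference between the two cores is not broken down here. In this assay compound 2 gives 933 nM. Compound 4 `CCCCn1ccc(-c2ccc(Oc3ccnc(C)c3)cc2F)c(C#N)c1=O` is not yet measured and differs from compound 2 by fluoro in place of chloro on an aromatic carbon. This is the same kind of change, but at a place ortho to a large group and meta to the (2-methylpyridin-4-yl)oxy group, whereas before it sat ortho to the (2-methylpyridin-4-yl)oxy group and meta to a large group. For compound 4 the expected step is a 1.7-fold higher number from compound 2 to compound 4 (0.23 log units; within the scatter), giving an estimated 1600 nM, between 650 nM and 4000 nM. This expectation rests on a 1.9-fold higher number from compound 1 to compound 3 (0.28 log units; within the scatter).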

Compound 4, half-maximal effective concentration: 390 nM
Beside the measured number, compound 4's estimate is 4.1-fold (0.61 log units) above it; measured number below the stated range.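

In this assay, the change from chloro to fluoro gives a 2.4-fold lower number from compound 2 to compound 4 (0.38 log units; beyond the scatter), so its effect does not carry over unchanged from one core to the other: the same change on two cores in this assay, a 1.9-fold higher number (0.28 log units; within the scatter) from compound 1 to compound 3 and a 2.4-fold lower number (0.38 log units; beyond the scatter) from compound 2 to compound 4, 4.6-fold (0.66 log units) apart, beyond the scatter of two such steps

Two pairs are enough to warn that a result on one core is a poor guide to the other in this series, but not enough to give a general rule. They also do not show why the steps differ: in compound 4 the fluoro sits ortho to a large group and meta to a (2-methylpyridin-4-yl)oxy group, but two pairs cannot tie the gap to that place.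

As far as these compounds go, whether a bromo or trifluoromethyl group at that place would follow the fluoro of compound 4 remains open. So does how the same swap behaves on any other core.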